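The compounds below may be only part of what the source reports. "The series", "measured", "known", "first", "only" and "open" are said of these compounds alone.

Working notes on the series. Compound 1 `CCc1nc(NC(CC)CC)c(Cl)nc1-c1ccc(Cl)cc1Cl` in an assay on IMR-32 cells for displacement of a labelled ligand from corticotropin-releasing factor receptor 1 (Homo sapiens), read by scintillation counting, with a stated time of 2 h (a lower number here means a stronger inhibitor, a higher number a weaker inhibitor), gives 71 nM. Going by the values given here, compound 2 `CCc1nc(NC(CC)CC)c(F)nc1-c1ccc(Cl)cc1Cl` in this assay gives 167 nM, the higher of the two numbers so far; the single step between them, a 2.4-fold higher number from compound 1 to compound 2 (0.37 log units; beyond the scatter), is fluoro in place of chloro on an aromatic carbon. Compound 3 `CCc1nc(-c2ccc(Cl)cc2Cl)c(CC)nc1NC(CC)CC` is not yet measured. Compared with compound 2 the change is ethyl in place of fluoro on an aromatic carbon next to the ring nitrogen, ortho to the (pentan-3-yl)amino group. Among the compounds with values here, the only measured step that bears on this position is a 2.4-fold higher number from compound 1 to compound 2 (0.37 log units; beyond the scatter), which shows that what sits there moves the number, with chloro giving the lower value in compound 1. For compound 3 a return toward the level of compound 1 is expected, that is a step of a 2.1-fold lower number from compound 2 to compound 3 (0.32 log units; beyond the scatter). The estimate for compound 3 in this assay is 80 nM, with a range of 30 nM to 250 nM.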

Compound 3, inhibition constant: 4.1 nM
Compound 3: the middle estimate sits 20-fold (1.29 log units) above what was measured; the measured number lies below the stated range.
By their numbers in this assay, from the lowest: compound 3; then compound 1; then compound 2.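

In this assay the position ortho to the (pentan-3-yl)amino group proves far more responsive than the halogen exchange alone indicated: ethyl in place of fluoro gives a 41-fold lower number from compound 2 to compound 3 (1.61 log units; beyond the scatter) and ethyl in place of chloro gives a 17-fold lower number from compound 1 to compound 3 (1.24 log units; beyond the scatter). Both steps are large, against the modest 2.4-fold higher number from compound 1 to compound 2 (0.37 log units; beyond the scatter), so ethyl at this position does not merely restore the level of the chloro compound but takes the number well past both halogen compounds. Nothing available here accounts for this gain.

Going by these compounds, whether a methyl group, a longer chain such as propyl, or a methoxy group at the same position would match or pass ethyl remains open. With only fluoro, chloro and ethyl compared, no trend with chain length can yet be drawn.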